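The source may hold more compounds than are shown below. What is called first, only, known or untested is meant among the compounds shown, and "the series" means these compounds.

Measured compounds:
compound 1 `C[C@@H](NC(=O)c1ccc(C#Cc2ccc(F)cc2)cn1)C(C)(C)O` gives 38.4% in an ADME assay on HEK293 cells for agonist activity at metabotropic glutamate receptor 5 (Rattus norvegicus), read by fluorescence and calcium flux; on this read-out higher numbers stand for larger maximal responses and lower numbers for smaller maximal responses
compound 2 `C[C@@H](NC(=O)c1ccc(C#Cc2ccc(F)cc2F)cn1)C(C)(C)O` gives 38.2% in this assay

Compound 2 stands lowest of the two numbers in this assay, with compound 1 nearest; the step of a number 0.2 percentage points lower from compound 1 to compound 2 (within the scatter) is within the scatter, so the two values are not distinguishable.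

Compound 3 `C[C@@H](NC(=O)c1ccc(C#Cc2cc(F)ccn2)cn1)C(C)(C)O` is not yet measured. It differs from compound 2 by 4-fluoropyridin-2-yl in place of 2,4-difluorophenyl on a triple-bonded carbon.

Among the measured compounds shown here, only one measured step exists, a number 0.2 percentage points lower from compound 1 to compound 2 (within the scatter), and it concerns a fluoro in place of hydrogen on an aromatic carbon, not a change of the ring itself. It bears on the present step only in showing that the fluorine pattern on this ring left the maximal response unchanged. For the measured compounds named here, no measured step covers exchange of the carbon-only ring for a ring with one hetero atom, so the expectation rests on the flat result so far. The step of a number 0.2 percentage points lower from compound 2 to compound 3 (within the scatter) is expected to stay within the scatter. For compound 3 the estimate in this assay is 38%, with a range from 24% to 52%.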

Compound 3, largest response reached (reported as efficacy), in percent of the reference or control that the assay uses: 33%
For compound 3 the middle estimate is 5 percentage points above the measured one; the range from low to high includes it.
By their numbers in this assay, from the lowest: compounds 3, 2 and 1 (each within the scatter of the next).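

In this assay, moving from a carbon-only ring to a six-membered aromatic ring with 1 hetero atom on the triple-bonded carbon gives a step within the scatter from either fluorinated phenyl group (4-fluoropyridin-2-yl in place of 2,4-difluorophenyl: a number 5.2 percentage points lower from compound 2 to compound 3 (within the scatter); in place of 4-fluorophenyl: a number 5.4 percentage points lower from compound 1 to compound 3 (within the scatter)). The earlier compounds shown here covered only a fluoro in place of hydrogen, whereas this change also brings in a hydrogen-bond acceptor on this ring, and the three values still cannot be told apart. No independent data on these compounds help to interpret this result.

The compounds shown leave open whether a saturated ring such as cyclohexyl, or a ring carrying an amine or a carboxylic acid, on the triple-bonded carbon would stay within the same range. They also leave open whether a pyridine without fluoro would do so.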